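Aryl ether swap on a cyclopentyl ketone series

The compounds below may be only part of what the source reports. "The series", "measured", "known", "first", "only" and "open" are said of these compounds alone.

Measured compounds:
compound 1 `Cc1c(OCCCCOc2ccccc2C(=O)O)ccc(C(=O)CC(C)C)c1O` — 415 nM
compound 2 `CCC(=O)c1ccc(OCCCCOc2ccc(F)c(C(=O)O)c2)c(C)c1O` — 124 nM
compound 3 `Cc1c(OCCCCOc2ccc(F)c(C(=O)O)c2)ccc(C(=O)CC2CCCC2)c1O` — 699 nM

In an assay on HEK293 cells for positive allosteric modulation of metabotropic glutamate receptor 2 (Rattus norvegicus), read by thallium flux, with a stated time of 2.5 min (a higher number here means that more compound is needed for the effect, a lower number that less compound is needed), compound 3 gives 699 nM, the highest number of the three. Its nearest neighbour is compound 1, which in this assay gives 415 nM, within the scatter of compound 3. Among the compounds with values here, the only single-point step recorded is a 5.6-fold higher number from compound 2 to compound 3 (0.75 log units; beyond the scatter), which separates compound 3 most clearly from compound 2.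

Compound 4 `COc1ccc(C(=O)O)cc1OCCCCOc1ccc(C(=O)CC2CCCC2)c(O)c1C` has not yet been measured. It differs from compound 3 by 5-carboxy-2-methoxyphenyl in place of 3-carboxy-4-fluorophenyl on an oxygen on a saturated carbon. Within the data shown here, no measured pair reports the same change: compound 1 carries a different carboxyphenyl, but also a different ketone chain, so its value speaks only to itself. Among the measured compounds shown here, the one step on record concerns the ketone side, not the aryl ether, and so it does not bear on this change. With nothing to point either way, the step from compound 3 to compound 4 in this assay is expected to stay within the scatter: a 1.0-fold higher number from compound 3 to compound 4 (0.00 log units; within the scatter). Compound 4 is therefore estimated at 700 nM, with a range from 250 nM to 2000 nM.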

Compound 4, half-maximal effective concentration: 425 nM
Compound 4: the middle estimate sits 1.6-fold (0.22 log units) above what was measured; measured number inside the range.
By their numbers in this assay, from the lowest: compound 2; then compounds 1, 4 and 3 (each within the scatter of the next).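

Exchanging 3-carboxy-4-fluorophenyl for 5-carboxy-2-methoxyphenyl on the oxygen on a saturated carbon gives a 1.6-fold lower number from compound 3 to compound 4 (0.22 log units; within the scatter) in this assay. Within the data shown here, this is the first reading of a change on the aryl ether side with the cyclopentyl ketone held constant, as the earlier step concerned only the ketone side. In this pair, the fluorine-bearing group and the methoxy-bearing group cannot be told apart, and nothing available gives a cause for that.

Going by these compounds, it remains open whether 5-carboxy-2-methoxyphenyl would read the same on the ketone chain of compound 2, which gives 124 nM in this assay. Also open, on these data alone, is how this position would respond to a tetrazole or a primary amide in place of the carboxylic acid, or to a longer chain between the two ether oxygens.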